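This account rests on a few compounds, and the source may have more. Where it says the series, first, only, none or still open, it means among the compounds named here.

Measured in a functional assay on HOP-62 cells (Homo sapiens) for antiproliferative activity, with a stated time of 48 h; on this read-out higher numbers stand for weaker inhibition of growth and lower numbers for stronger inhibition of growth:
compound 1, `Cc1cc(O)c(C2=NN(c3ccc(S(N)(=O)=O)cc3)C(c3ccccc3O)C2)cc1Cl`, 1930 nM
compound 2, `Cc1cc(O)c(C2=NN(c3ccc(S(N)(=O)=O)cc3)C(c3ccccc3Cl)C2)cc1Cl`, 2030 nM
compound 3, `Cc1cc(O)c(C2=NN(c3ccc(S(N)(=O)=O)cc3)C(/C=C/c3ccccc3)C2)cc1Cl`, 3940 nM

Compound 3 stands apart from compound 1 alone: the step of a 2.0-fold higher number from compound 1 to compound 3 (0.31 log units; beyond the scatter) lies beyond the scatter, whereas a 1.9-fold higher number from compound 2 to compound 3 (0.29 log units; within the scatter) stays within it, and a 1.1-fold higher number from compound 1 to compound 2 (0.02 log units; within the scatter) also falls within the scatter. Compound 4 `COc1ccc(C2CC(c3cc(Cl)c(C)cc3O)=NN2c2ccc(S(N)(=O)=O)cc2)cc1OC` has not yet been measured; it differs from compound 3 by 3,4-dimethoxyphenyl in place of 2-phenylethenyl on a saturated ring carbon. This change places an aromatic ring on the saturated ring carbon again, as in compound 1 and compound 2, so the two steps toward compound 3 bear on it in reverse. Compound 4 is therefore expected to give a modestly lower number in this assay than compound 3, a 1.8-fold lower number from compound 3 to compound 4 (0.25 log units; within the scatter). The estimate for compound 4 is 2200 nM, expected to fall between 1100 nM and 4400 nM.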

Compound 4, concentration for 50% growth inhibition: 3920 nM
The estimate for compound 4 lay 1.8-fold (0.25 log units) below the measured number, within the range that was stated.
By their numbers in this assay, from the lowest: compounds 1, 2, 4 and 3 (each within the scatter of the next, the first and the last beyond it).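

In this assay, 3,4-dimethoxyphenyl on the saturated ring carbon reads the same as 2-phenylethenyl, with a 1.0-fold lower number from compound 3 to compound 4 (0.00 log units; within the scatter), so an aromatic ring on that carbon does not by itself restore the number of compound 1. Against the 2-chlorophenyl group the step also stays small, at a 1.9-fold higher number from compound 2 to compound 4 (0.29 log units; within the scatter), and only the 2-hydroxyphenyl comparison, a 2.0-fold higher number from compound 1 to compound 4 (0.31 log units; beyond the scatter), passes the scatter, and modestly. No measurement on hand explains these steps. The compounds shown leave open how an amine, a carboxylic acid or a longer chain on this carbon would read in this assay.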